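The compounds below may be only part of what the source reports. "The series", "measured", "known", "first", "only" and "open" are said of these compounds alone.

Measured so far:
compound 1, `COc1ccc(-c2[nH]c3ccccc3c2/C=C(\C#N)S(=O)(=O)c2ccccc2)cc1`, 2300 nM in a functional assay on HOP-92 cells (Homo sapiens) for inhibition, read by sulforhodamine B assay, with a stated time of 48 h; a lower number here means a stronger inhibitor of growth, a higher number a weaker inhibitor of growth
compound 2, `COc1ccc(-c2[nH]c3ccc(OC)cc3c2/C=C(\C#N)S(=O)(=O)c2ccccc2)cc1`, 698 nM

Compound 2 stands lowest of the two numbers; the nearest, compound 1, gives the higher one, and the step of a 3.3-fold lower number from compound 1 to compound 2 (0.52 log units; beyond the scatter) lies beyond the scatter. Compound 3, `COc1ccc2[nH]c(-c3ccccc3)c(/C=C(\C#N)S(=O)(=O)c3ccccc3)c2c1`, is not yet measured. It differs from compound 2 by hydrogen in place of methoxy on an aromatic carbon, on the aromatic carbon of the six-membered ring of carbon only. Within the data shown here, only the step from compound 1 to compound 2 bears on this, and it concerns a methoxy at another place. Its size suggests that losing a methoxy gives a modestly higher number. Compound 3 is therefore expected to show a step of a 1.9-fold higher number from compound 2 to compound 3 (0.27 log units; within the scatter), with an estimate of 1300 nM between 500 nM and 3500 nM.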

Compound 3, concentration for 50% growth inhibition: 6100 nM
Estimate against measurement, compound 3: 4.7-fold (0.67 log units) below; measured number above the stated range.
By their numbers in this assay, from the lowest: compound 2; then compound 1; then compound 3.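

In this assay the 4-methoxyphenyl group proves to matter: replacing it with phenyl gives an 8.7-fold higher number from compound 2 to compound 3 (0.94 log units; beyond the scatter) and so this methoxy counts for growth inhibition as well. That step is larger than a 3.3-fold lower number from compound 1 to compound 2 (0.52 log units; beyond the scatter) and the latter concerns a methoxy at another place, so the two places do not count alike here. Nothing measured here accounts for the difference. Still open, on these data alone, is whether an amine, a hydroxyl or a chlorine at this place would keep the number as low as methoxy does. Also open, as far as these compounds go, is whether the loss would be as large without the other methoxy.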